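The compounds below may be only part of what the source reports. "The series", "measured", "known", "first", "only" and "open" are said of these compounds alone.

Measured so far in a functional assay (QGY7701 cells, Homo sapiens) for inhibition, read by MTT assay, with a stated time of 48 h; a higher number here means a weaker inhibitor, a lower number a stronger inhibitor:

- compound 1 `COc1ccc2c(=O)c(/C=C/C(=O)Nc3ccccc3)coc2c1` gives 14000 nM
- compound 2 `COc1ccc2c(=O)c(/C=C/C(=O)NCc3ccc(C)cc3)coc2c1` gives 10200 nM
- compound 3 `Cc1ccc(CNC(=O)/C=C/c2coc3cc(O)ccc3c2=O)cc1` gives 24900 nM

Compound 3 gives the highest of the three numbers, but its gap to compound 1 lies within the scatter, so no order is drawn between those two. Going by the values given here, the only step beyond the scatter is a 2.4-fold higher number from compound 2 to compound 3 (0.39 log units; beyond the scatter). The other measured step, a 1.4-fold higher number from compound 2 to compound 1 (0.14 log units; within the scatter), goes with phenyl in place of 4-methylbenzyl on an amide-type nitrogen and stays within the scatter.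

Compound 4 `O=C(/C=C/c1coc2cc(O)ccc2c1=O)Nc1ccccc1` has not yet been measured in this assay. Among the compounds with values here, it differs from compound 3 by phenyl in place of 4-methylbenzyl on an amide-type nitrogen, the same change as the one from compound 2 to compound 1, made at a place described in identical words. The cores of the two pairs differ by hydrogen in place of methyl on an oxygen on an aromatic ring.

Since the same change on the methoxy core gave only a 1.4-fold higher number from compound 2 to compound 1 (0.14 log units; within the scatter), a step of similar small size is expected here: a 1.4-fold higher number from compound 3 to compound 4 (0.15 log units; within the scatter). Compound 4 is thus expected to give about 35000 nM in this assay, with a likely range from 16000 nM to 80000 nM.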

Compound 4, half-maximal inhibitory concentration: 17900 nM
For compound 4 the middle estimate is 2.0-fold (0.29 log units) above the measured one; low and high end bracket the measured number.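

In this assay, phenyl in place of 4-methylbenzyl on an amide-type nitrogen gives a 1.4-fold lower number from compound 3 to compound 4 (0.14 log units; within the scatter), and the comparison with the same change on the core of compound 2 finds no difference between the cores: the same change on two cores in this assay, a 1.4-fold higher number (0.14 log units; within the scatter) from compound 2 to compound 1 and a 1.4-fold lower number (0.14 log units; within the scatter) from compound 3 to compound 4, 1.9-fold (0.28 log units) apart, within the scatter of two such steps. Hydrogen in place of methyl on an oxygen on an aromatic ring gives a 1.3-fold higher number from compound 1 to compound 4 (0.11 log units; within the scatter), and although the earlier step with this change lies beyond the scatter, the two steps cannot be told apart: the same change on two cores in this assay, a 2.4-fold higher number (0.39 log units; beyond the scatter) from compound 2 to compound 3 and a 1.3-fold higher number (0.11 log units; within the scatter) from compound 1 to compound 4, 1.9-fold (0.28 log units) apart, within the scatter of two such steps. These two pairs are thus compatible with each change carrying over from one core to the other, but they do not prove it, and with so few steps, most of them within the scatter, no direction or size can be assigned to the phenyl change on either core.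

On these data alone, whether a change with a step clearly beyond the scatter on the amide-type nitrogen would carry over between these cores remains open. Also open, as far as these compounds go, is how the series would respond there to a longer chain, an amine or a carboxylic acid.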